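Swapping methoxy for chloro on the shared core

The source may report more compounds than this note shows. Statements on the series, on what has been measured and on what is new or still open speak of the compounds shown alone.

Two compounds from this series have been run in an ADME assay on microsomes from liver (Rattus norvegicus) for metabolic stability, read by LC-MS, using NADPH, with a stated time of 10 min, tested at 0.5 uM (a lower number here means that less of the compound is left, a higher number that more of the compound is left), so far. Compound 1, with the structure `CC(=O)Nc1cc(-c2ccc(OC[C@@](C)(N)CC(C)C)c(F)c2)ccn1`, is the one of the two that retains the more; in this assay compound 1 gives 92%. Compound 2, with the structure `COC(=O)Nc1cc(-c2cnc(OC[C@@](C)(N)CC(C)C)c(OC)c2)ccn1`, stands at the lower end of the two numbers; in this assay compound 2 gives 79%, which is beyond the usual scatter from compound 1. These two differ in several places at once, so no single change between them can be read off.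

Compound 3, with the structure `COC(=O)Nc1cc(-c2cnc(OC[C@@](C)(N)CC(C)C)c(Cl)c2)ccn1`, has not yet been measured in this assay. It differs from compound 2 in one place: chloro in place of methoxy on an aromatic carbon. Going by the values given here, nothing among the measured pairs shows what this particular exchange does. Among the compounds with values here, with no such step in hand, the expectation is that the change from compound 2 to compound 3 stays within the scatter, in either direction. Compound 3 is therefore estimated at 82%, with a range from 65% to 95%, a step of a number 3 percentage points higher from compound 2 to compound 3 (within the scatter) that is expected rather than known.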

Compound 3, percent of the compound remaining: 73%
Compound 3: the middle estimate sits 9 percentage points above what was measured; low and high end bracket the measured number.
By their numbers in this assay, from the lowest: compounds 3 and 2 (each within the scatter of the next); then compound 1.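

In this assay, going by these compounds alone, putting chloro in place of methoxy on the aromatic carbon ortho to the (2-amino-2,4-dimethylpentyl)oxy group gives a number 6 percentage points lower from compound 2 to compound 3 (within the scatter), and this is the first step that isolates a single place. It shows that, at this position two atoms from the ring nitrogen, the read-out does not separate chloro from methoxy, even though the exchange takes away the hydrogen-bond acceptor that methoxy carries and replaces an oxygen-linked group with a single chlorine atom. Nothing at hand explains this outcome or shows how either group acts at this position.

On these data alone, the pair covers only these two groups, so it remains open whether an amine, a nitrile or a longer alkoxy chain such as ethoxy on the same aromatic carbon would also stay within the scatter of compound 2 or would move beyond it. Within the data shown here, it also remains open whether the same exchange of methoxy for chloro would give a comparable step on a different core, since this single pair is the only instance of it.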